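A few compounds are considered here, and "the series" means these few. Any claim that something is new, unique, unknown or untested is made for them only; others in the source may bear on it.

Of the compounds shown here, two in this set have been measured. Compound 1 `Fc1ccc2nc(-c3cncnc3)n(C3CC3)c2c1` gives 40 nM in an assay on cells for inhibition of cytochrome P450 11B2, mitochondrial (Homo sapiens), read by HPLC, with a stated time of 90 min; on this read-out higher numbers stand for weaker inhibition and lower numbers for stronger inhibition. Compound 2 `N#Cc1ncncc1-c1nc2cc(F)c(F)cc2n1C1CC1`, whose shared core carries two fluorine atoms and a cyano group on the six-membered aromatic ring with 2 nitrogen, gives 13 nM in this assay. Of the two numbers seen so far, compound 2 has the lower one, and its gap to compound 1 lies beyond the scatter of repeat runs. Compound 3 `CC(F)(F)c1ncncc1-c1nc2cc(F)c(F)cc2n1C1CC1` takes one step away from compound 2: 1,1-difluoroethyl in place of cyano on an aromatic carbon. Among the compounds with values here, no measured pair shows what such a swap does here, so the expected step from compound 2 to compound 3 in this assay is a modest weakening, a 1.9-fold higher number from compound 2 to compound 3 (0.28 log units; within the scatter), with a real chance of no change beyond the scatter. Compound 3 is therefore expected to give 25 nM, within a range from 8 nM to 80 nM.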

Compound 3, half-maximal inhibitory concentration: 50 nM
The estimate for compound 3 lay 2.0-fold (0.30 log units) below the measured number; measured number inside the range.
By their numbers in this assay, from the lowest: compound 2; then compounds 1 and 3 (each within the scatter of the next).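

Within the data shown here, this pair gives the first direct reading of this position: in this assay, 1,1-difluoroethyl in place of cyano, on an aromatic carbon next to the ring nitrogen, gives a 3.8-fold higher number from compound 2 to compound 3 (0.59 log units; beyond the scatter), a step beyond the scatter of repeat runs. The position therefore responds to what it carries, and the group with 4 heavy atoms and no hydrogen-bond acceptor goes with weaker inhibition than cyano, though the step is modest. Nothing measured here tells why the number rises.

A single pair cannot separate which of the differences between the two groups matters. Going by these compounds, how a methyl group, a methoxy group or an amine on this same aromatic carbon would read in this assay stays open, as does whether this step would hold on another core.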